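Swapping the Aryl Group on a Shared Core

A few compounds are considered here, and "the series" means these few. Any claim that something is new, unique, unknown or untested is made for them only; others in the source may bear on it.

Compound 1 `CCOC(=O)c1cnn(-c2nc(-c3cccc(OC)c3OC)c(C#N)c(=O)n2C)c1N`, compound 2 `CCOC(=O)c1cnn(-c2nc(-c3ccc(N(C)C)cc3)c(C#N)c(=O)n2C)c1N` and compound 3 `CCOC(=O)c1cnn(-c2nc(-c3cccs3)c(C#N)c(=O)n2C)c1N` share one core and differ only in the aryl group attached to it. In a functional assay, with a stated time of 150 min (a higher number here means a weaker inhibitor, a lower number a stronger inhibitor), compound 1 gives 69 ug/mL, compound 2 gives 115 ug/mL and compound 3 gives 98 ug/mL. Compound 3 thus holds the second highest of the three numbers, nearest to compound 2 and furthest from compound 1, though neither of those gaps goes beyond the scatter of the measurement.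

Compound 4 `CCOC(=O)c1cnn(-c2nc(-c3ccccc3Cl)c(C#N)c(=O)n2C)c1N` continues the series with the change (2-chlorophenyl in place of thiophen-2-yl on an aromatic carbon).

Among the compounds with values here, three measured steps bear on this change, each an exchange of the aryl group at the same position of the core: a 1.7-fold higher number from compound 1 to compound 2 (0.22 log units; within the scatter), a 1.4-fold higher number from compound 1 to compound 3 (0.15 log units; within the scatter) and a 1.2-fold lower number from compound 2 to compound 3 (0.07 log units; within the scatter). None of them left the scatter, so exchanging one aryl group for another at this position has so far moved this assay little in either direction, whatever the ring brought in. The step expected is therefore a 1.1-fold lower number from compound 3 to compound 4 (0.04 log units; within the scatter), nothing beyond the scatter. In this assay compound 4 is expected at 90 ug/mL, within a range from 45 ug/mL to 180 ug/mL.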

Compound 4, half-maximal inhibitory concentration: 93 ug/mL
Beside the measured number, compound 4's estimate is 1.0-fold (0.01 log units) below it; measured number inside the range.
By their numbers in this assay, from the lowest: compounds 1, 4, 3 and 2 (each within the scatter of the next).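

Among the compounds shown, compound 4 alone carries chlorine, and replacing the five-membered thiophen-2-yl ring with the six-membered 2-chlorophenyl ring gives a 1.1-fold lower number from compound 3 to compound 4 (0.02 log units; within the scatter) in this assay. Set against the two other aryl groups, the same 2-chlorophenyl gives a 1.2-fold lower number from compound 2 to compound 4 (0.09 log units; within the scatter) and a 1.3-fold higher number from compound 1 to compound 4 (0.13 log units; within the scatter), so the position now tolerates a chlorine-bearing ring, a sulfur-bearing ring, a dimethylamino-bearing ring and a dimethoxy-bearing ring with every pairwise step inside the scatter, and no aryl group of the four can be ranked over another. Nothing available explains why these steps stay so small.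

On these data alone, all four compounds place an aromatic ring at this position, so it remains open whether a group of another kind there, such as a simple amine, a carboxylic acid or a longer alkyl chain, would produce a step beyond the scatter. The ethyl ester, the amino group and the nitrile are also common to all four compounds, which leaves the response of this assay to a change at any of those places unknown.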